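A few compounds are considered here, and "the series" means these few. Any claim that something is new, unique, unknown or untested is made for them only; others in the source may bear on it.

Compound 1 `CCC(c1cc2cccnc2cc1F)n1cnc2ncc(-c3cnn(C)c3)nc21`: "not determined" (no result reported)
Compound 2 `OCCn1cc(-c2cnc3ncn(Cc4ccc5ncccc5c4)c3n2)cn1`: 2330 nM
Compound 3 `Cc1cc2ncccc2cc1C(C)n1cnc2ncc(-c3ccc(C(N)=O)c(F)c3)nc21`: "not determined" (no result reported)

Among the measured compounds shown here, in a functional assay on NCI-H1993 cells (Homo sapiens) for inhibition, read by CCK-8 assay, with a stated time of 72 h (on this read-out higher numbers stand for weaker inhibition and lower numbers for stronger inhibition), compound 2 gives 2330 nM, the only number available, as compound 1 and compound 3 have no reported result. Compound 4 `FC(F)(F)c1ccc(-c2cnc3ncn(Cc4ccc5ncccc5c4)c3n2)cc1` keeps the core of compound 2 but carries 4-(trifluoromethyl)phenyl in place of 1-(2-hydroxyethyl)-1H-pyrazol-4-yl on an aromatic carbon. For the measured compounds named here, no measured pair shows what such a change does in this assay, so the expectation is uncertain and rests only on this swap and the single value of compound 2. A modest move toward weaker inhibition is expected, and the estimated step is a 1.9-fold higher number from compound 2 to compound 4 (0.29 log units; within the scatter). For compound 4 the estimated value is 4500 nM, with an expected range of 1200 nM to 17000 nM.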

Compound 4, half-maximal inhibitory concentration: > 10000 nM
Compound 4 gave a limit, no number; the forecaster's own chance of this, stated with the estimate: 20%; middle value at least 2.2-fold (0.34 log units) away from the limit.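

In this assay, 4-(trifluoromethyl)phenyl in place of 1-(2-hydroxyethyl)-1H-pyrazol-4-yl gives an at least 4.2-fold higher number from compound 2 to compound 4 (0.63 log units; beyond the scatter), so the group on this aromatic carbon does affect inhibition. The result for compound 4 is a limit and not a number: the limit of > 10000 nM in this assay, at which 1 of the 4 values shown sits.

This one swap changes the ring and the hydrogen-bond donor and acceptor counts together, and it cannot show which of these differences counts. It also leaves open how an amine or a carboxylic acid in place of the hydroxyl of the 2-hydroxyethyl chain, or a longer chain, would read.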